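The source may report more compounds than this note shows. Statements on the series, on what has been measured and on what is new or still open speak of the compounds shown alone.

Notes on the series in an ADME assay on PBMC cells (Homo sapiens) for cytotoxicity; a lower number here means that less compound is tolerated, a higher number that more compound is tolerated. Compound 1 `CC(CCNC(=O)c1c(Cl)cncc1Cl)N1CCC(C(Oc2cccc(C#N)n2)c2ccc(C(F)(F)F)cc2)CC1` gives 15700 nM. Compound 3 `COc1cccc(OC(c2ccc(C(F)(F)F)cc2)C2CCN(C(C)CCNC(=O)c3c(Cl)cncc3Cl)CC2)n1` gives 32700 nM. Compound 2 `CCO/N=C(/c1ccc(Br)cc1)C1CCN(C(C)CCN(C)C(=O)c2c(C)cc[n+]([O-])c2C)CC1`, built differently in several places, reaches only the limit of the assay, > 182000 nM, and no number is read for it (the limit of > 182000 nM in this assay, at which 1 of the 3 values shown sits). The single measured step among these is a 2.1-fold higher number from compound 1 to compound 3 (0.32 log units; beyond the scatter). Compound 3 thus holds the higher of the two read numbers, with compound 1 the nearest neighbour; the third value is a limit and is not ranked.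

Compound 4 `CC(CCNC(=O)c1c(Cl)cncc1Cl)N1CCC(C(Oc2cc(Cl)ccn2)c2ccc(C(F)(F)F)cc2)CC1` is the next step from compound 3: 4-chloropyridin-2-yl in place of 6-methoxypyridin-2-yl on an oxygen on a saturated carbon. Among the compounds with values here, the only measured step that touches the same ring is a 2.1-fold higher number from compound 1 to compound 3 (0.32 log units; beyond the scatter), a modest change in one substituent; the move to compound 4 exchanges the whole ring on that oxygen, which no measured pair covers directly, so it is read only as a guide to size. A step of about that modest scale is expected for compound 4, with the direction uncertain, and a 1.5-fold lower number from compound 3 to compound 4 (0.17 log units; within the scatter) is the step the estimate implies. Compound 4 is therefore expected to give 22000 nM, within 9000 nM to 55000 nM.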

Compound 4, half-maximal cytotoxic concentration: 4260 nM
Beside the measured number, compound 4's estimate is 5.2-fold (0.71 log units) above it; the whole stated range lies above it.
By their numbers in this assay, from the lowest: compound 4; then compound 1; then compound 3. At a limit, above all of these: compound 2.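

In this assay, the group on the oxygen on a saturated carbon carries more of the read-out than the substituent change alone suggested: a 7.7-fold lower number from compound 3 to compound 4 (0.89 log units; beyond the scatter), whereas the earlier change within the 6-substituted pyridin-2-yl pair was only a 2.1-fold higher number from compound 1 to compound 3 (0.32 log units; beyond the scatter). The result also holds against the other 6-substituted ring, with a 3.7-fold lower number from compound 1 to compound 4 (0.57 log units; beyond the scatter), so 4-chloropyridin-2-yl gives the lowest of the three read numbers and both 6-substituted rings stand apart from it beyond the scatter. No measurement shown here bears on the cause of this shift.

Since 4-chloropyridin-2-yl differs from 6-methoxypyridin-2-yl in both the substituent and where it stands on the ring, the compounds shown do not separate these two changes. As far as these compounds go, it remains open whether 6-chloropyridin-2-yl on the same oxygen would read with compound 4 or with compound 3, and whether 4-methoxypyridin-2-yl or 4-aminopyridin-2-yl would keep the low number, which would tie it to the ring position rather than to the chlorine.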